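The compounds below may be only part of what the source reports. "The series", "measured", "known", "first", "only" and "open" are said of these compounds alone.

In a functional assay on EA.hy 926 cells (Homo sapiens), read by fluorescence, tested at 10 uM (a higher number here means a stronger effect of the compound at the concentration tested, a lower number a weaker effect), three compounds have been measured. Compound 1 `CCC(C)NC(=C\C(=O)/C=C/c1ccc(O)c(OC)c1)/C=C/c1ccc(O)c(OC)c1` gives 184%. Compound 2 `COc1cc(/C=C/C(=O)/C=C(/C=C/c2ccc(OC(C)=O)c(OC)c2)NCC(C)C)ccc1OC(C)=O` gives 240%, and compound 3 `COc1cc(/C=C/C(=O)/C=C(/C=C/c2ccc(O)c(OC)c2)NCC(C)C)ccc1O` gives 100%. Compound 3 and compound 1 differ in one place: sec-butyl in place of isobutyl on an amine nitrogen. That single change produced a number 84 percentage points higher from compound 3 to compound 1 (beyond the scatter). The difference between the core of compound 2 and the core of compound 3 is not broken down here. Compound 4 `CCC(C)NC(=C\C(=O)/C=C/c1ccc(OC(C)=O)c(OC)c1)/C=C/c1ccc(OC(C)=O)c(OC)c1` has not yet been measured; it differs from compound 2 by sec-butyl in place of isobutyl on an amine nitrogen, the same change at the same place. Among the measured compounds shown here, the expected step is a number 60 percentage points higher from compound 2 to compound 4 (beyond the scatter), of similar size, because the one comparable change seen so far gave a number 84 percentage points higher from compound 3 to compound 1 (beyond the scatter), although compound 2 already stands highest of the three and the read-out may not rise as far again. Compound 4 is therefore estimated at 300%, between 230% and 380%.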

Compound 4, a percentage reported as activity, at one concentration (the size of the read-out at that concentration, not a potency): 105%
Compound 4: middle estimate off by 195 percentage points, on the high side, outside the stated range (below it).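

In this assay, the swap of isobutyl for sec-butyl on the amine nitrogen gave a number 135 percentage points lower from compound 2 to compound 4 (beyond the scatter) and so did not repeat the rise seen on the other core, and the two steps clearly differ: the same change on two cores in this assay, a number 84 percentage points higher (beyond the scatter) from compound 3 to compound 1 and a number 135 percentage points lower (beyond the scatter) from compound 2 to compound 4, 219 percentage points apart, beyond the scatter of two such steps

The effect of this change therefore depends on the core that carries it, and a step seen on one core cannot simply be added to another in this series. These two pairs do not show which part of the cores is responsible or why the direction reverses.

As far as these compounds go, it remains open whether a straight butyl chain or a benzyl group on the same nitrogen would also move the read-out in opposite directions on the two cores.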